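Toxicity check: swapping a methoxy for a (difluoromethyl)sulfanyl group

This account rests on a few compounds, and the source may have more. Where it says the series, first, only, none or still open, it means among the compounds named here.

Compound 1 `Cc1ccc2cc(C(C)N(Cc3ccc(F)cc3)Cc3ccc(C(C)C)cc3)c(=O)[nH]c2c1` gives > 33000 nM in a toxicity assay on MDCK cells (Canis lupus familiaris) for cytotoxicity, read by crystal violet staining, with a stated time of 48 h; a higher number here means that more compound is tolerated, a lower number that less compound is tolerated.
Compound 2 `Cc1ccc2cc(CN(Cc3ccc(Cl)cc3)Cc3ccc(Cl)cc3)c(=O)[nH]c2c1` gives > 33000 nM in this assay.
Compound 3 `COc1ccc(CN(Cc2ccc(C(C)(C)C)cc2)Cc2cc3cc(C)ccc3[nH]c2=O)cc1` gives > 10000 nM in this assay.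

Each of these three values is a limit of the assay, not a measured number. Compound 3 sits at the limit of > 10000 nM in this assay, at which 1 of the 3 values shown sits, so its toxicity could not be pinned down; the other two compounds sit at the limit of > 33000 nM in this assay, at which 2 of the 3 values shown sit. Compound 4 `Cc1ccc2[nH]c(=O)c(CN(Cc3ccc(SC(F)F)cc3)Cc3ccc(C(C)(C)C)cc3)cc2c1` differs from compound 3 by (difluoromethyl)sulfanyl in place of methoxy on an aromatic carbon. With all three measured compounds showing no toxicity up to the tested limit, no step beyond the usual scatter is expected from compound 3 to compound 4 in this assay. The step that the limit leaves unreadable from compound 3 to compound 4 is the estimate. Compound 4 is expected to give about 25000 nM, within 8000 nM to 60000 nM, most likely again reported only as a limit.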

Compound 4, half-maximal cytotoxic concentration: > 5000 nM
Compound 4: a limit, no number (the forecaster's own chance of this, stated with the estimate: 80%); the middle value lies beyond the limit too.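

Compound 3 and compound 4 both stand only as limits in this assay; the step between them cannot be read. The compounds shown leave open at what concentration any of them becomes toxic to these cells.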